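Anilines versus saturated amines on a shared quinone-like core

A few compounds are considered here, and "the series" means these few. Any claim that something is new, unique, unknown or untested is made for them only; others in the source may bear on it.

Compound 2 `O=C1C=C(NC2CCCC2)C(=O)c2c1nc1n2[C@H]2OC[C@@H](O)[C@H]2OC1` is the starting point. In a functional assay on MCF7 cells (Homo sapiens) for inhibition, read by sulforhodamine B assay (on this read-out higher numbers stand for weaker inhibition and lower numbers for stronger inhibition), compound 2 yields only a limit, > 16000 nM. Compound 1 `Cc1ccc(NC2=CC(=O)c3c(nc4n3[C@H]3OC[C@@H](O)[C@H]3OC4)C2=O)cc1C` gives 4950 nM in this assay. Compound 3 `O=C1C(N2CCC2)=CC(=O)c2c1nc1n2[C@H]2OC[C@@H](O)[C@H]2OC1` likewise stops at a limit of > 16000 nM. Two of the three values rest at the same boundary (the limit of > 16000 nM in this assay, at which 2 of the 3 values shown sit), so compound 2 stands at the weak end of what was measured. Among the compounds with values here, the single one-place step, an at least 3.2-fold higher number from compound 1 to compound 3 (0.50 log units; beyond the scatter), runs from an arylamino group to a small saturated amine and weakens inhibition. Compound 4 `O=C1C=C(Nc2cccc(Cl)c2)C(=O)c2c1nc1n2[C@H]2OC[C@@H](O)[C@H]2OC1` differs from compound 2 by 3-chlorophenyl in place of cyclopentyl on an amine nitrogen. That change moves in the opposite sense, so a gain is expected, an at least 2.6-fold lower number from compound 2 to compound 4 (0.42 log units; beyond the scatter). Compound 4 is estimated at 6000 nM, within 2000 nM to 16000 nM.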

Compound 4, half-maximal inhibitory concentration: 4720 nM
Compound 4: the middle estimate sits 1.3-fold (0.10 log units) above what was measured; measured number inside the range.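

With the amine nitrogen kept and only the group on it exchanged, 3-chlorophenyl for cyclopentyl, this assay shows an at least 3.3-fold lower number from compound 2 to compound 4 (0.53 log units; beyond the scatter). Within the data shown here, the earlier step replaced a whole arylamino group with azetidin-1-yl, so this is the first reading of a change in the group on that nitrogen alone. The size of this gain has only a lower bound, and its full extent stays unknown: the limit of > 16000 nM in this assay, at which 2 of the 4 values shown sit.

The compounds shown leave open what the chlorine itself contributes. They also leave open whether an unsubstituted phenyl or a benzyl group on the same nitrogen would keep the gain.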